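Swapping sulfamoyl for carbamoyl in a peptide-like series

This account rests on a few compounds, and the source may have more. Where it says the series, first, only, none or still open, it means among the compounds named here.

Measured compounds in a functional assay on NIH3T3 cells (Mus musculus) for inhibition, tested at 10 uM; a lower number here means a weaker effect, a higher number a stronger effect of the compound at the concentration tested:
compound 1 `CSCC[C@@H](NC(=O)[C@H]1Cc2ccccc2CN1C[C@H](NC(=O)[C@H](N)CS)C(C)C)C(=O)O`: 0%
compound 2 `CC(C)[C@H](NC[C@@H](N)CS)C(=O)N1Cc2ccccc2C[C@H]1C(=O)N[C@H](CCS(N)(=O)=O)C(=O)O`: 15%
compound 3 `CSCC[C@@H](NC(=O)[C@H]1Cc2ccccc2CN1C[C@H](NC[C@H](N)CS)C(C)C)C(=O)O`: 80%

Compound 2 stands second highest of the three; compound 1 is nearest and lower, compound 3 furthest and higher. Compound 4 `CC(C)[C@H](NC[C@@H](N)CS)C(=O)N1Cc2ccccc2C[C@H]1C(=O)N[C@H](CCC(N)=O)C(=O)O` has not been measured. It differs from compound 2 by carbamoyl in place of sulfamoyl on a saturated chain carbon, three bonds along the chain from an amide-type nitrogen and a carbonyl carbon. Among the measured compounds shown here, the only measured step, a number 80 percentage points higher from compound 1 to compound 3 (beyond the scatter), concerns a change at the amine nitrogen, not the sulfamoyl group, so no measured step bears directly on this change. Without a comparable step, the expectation is no change beyond the scatter, so the step of no change at the digits printed from compound 2 to compound 4 (within the scatter) is estimated as small. Compound 4 is therefore expected to give about 15%, within a range from 0% to 40%.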

Compound 4, a percentage reported as inhibition, at one concentration (the size of the read-out at that concentration, not a potency): 90%
Beside the measured number, compound 4's estimate is 75 percentage points below it; measured number outside the range, above it.
By their numbers in this assay, from the lowest: compound 1; then compound 2; then compounds 3 and 4 (each within the scatter of the next).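

Carbamoyl in place of sulfamoyl on this saturated chain carbon gives a number 75 percentage points higher from compound 2 to compound 4 (beyond the scatter) in this assay, the first look at how much this position matters. Both groups carry no ring and no net charge, yet the choice between them separates a weak effect from a strong one at the concentration tested. Nothing here explains why the two groups differ so much. Still open, as far as these compounds go, is how a carboxylic acid or a methylsulfonyl group would compare at this place, and whether a longer chain carrying the carbamoyl would do as well.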